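An Amide in Place of an Ether at a Ring Carbon

The source may report more compounds than this note shows. Statements on the series, on what has been measured and on what is new or still open speak of the compounds shown alone.

Compound 1, `Cc1nn(-c2ncnc3nc[nH]c23)c2c1C(C(=O)Nc1ccccc1)CC(=O)N2`: 10 nM in a functional assay on HEK293 cells for agonist activity at G-protein coupled receptor 39 (Homo sapiens), read by scintillation proximity assay and inositol phosphate accumulation, with a stated time of 75 min, in the presence of a further agent that is not named here; a higher number here means that more compound is needed for the effect, a lower number that less compound is needed
Compound 2, `Cc1nn(-c2ncnc3nc[nH]c23)c2c1C(OCc1ccc(F)cc1)CC(=O)N2`: 1 nM in this assay

Compound 2 stands at the lowest of the two numbers, set apart from compound 1 by the step of a 10-fold lower number from compound 1 to compound 2 (1.00 log units; beyond the scatter). Compound 3, `Cc1nn(-c2ncnc3nc[nH]c23)c2c1C(NC(=O)c1ccccc1)CC(=O)N2`, carries benzamido in place of (4-fluorobenzyl)oxy on a saturated ring carbon. Within the data shown here, only that one step bears on this change: there an amide gave way to an ether, and compound 3 brings an amide back, though with its hydrogen-bond donor and carbonyl placed differently from compound 1. A move back toward the number of compound 1 is therefore expected, namely an 8.0-fold higher number from compound 2 to compound 3 (0.90 log units; beyond the scatter). Compound 3 is estimated at 8 nM, ranging from 2 nM to 40 nM.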

Compound 3, half-maximal effective concentration: 3 nM
Beside the measured number, compound 3's estimate is 2.7-fold (0.43 log units) above it; the range from low to high includes it.
By their numbers in this assay, from the lowest: compound 2; then compound 3; then compound 1.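

Moving the amide at this saturated ring carbon changes the number: with benzamido in place of phenylcarbamoyl there is a 3.3-fold lower number from compound 1 to compound 3 (0.52 log units; beyond the scatter) and so the two amides are not equivalent here. Benzamido still does not match (4-fluorobenzyl)oxy, with a 3.0-fold higher number from compound 2 to compound 3 (0.48 log units; beyond the scatter) as the step. Nothing available here explains either step.

That last step changes the link and removes the fluorine together, so a 4-fluorobenzamido group would be needed to separate the two. On these data alone, how an amine, a carboxylic acid or a longer chain would fare on this ring carbon remains open.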